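From 3-methoxyphenyl to 4-methoxyphenyl on compound 1

This account rests on a few compounds, and the source may have more. Where it says the series, first, only, none or still open, it means among the compounds named here.

Compound 1 `COc1cccc(/C=C/C(=O)/C=C/c2ccc(OCc3cn(CCOc4cc(=O)oc5ccccc45)nn3)c(OC)c2)c1` gives 7130 nM
Compound 2 `COc1cc(/C=C/C(=O)/C=C/c2ccco2)ccc1OCc1cn(CCOc2cc(=O)oc3ccccc23)nn1` gives 7870 nM
Compound 3 `COc1cc(/C=C/C(=O)/C=C/c2cc(OC)c(OC)c(OC)c2)ccc1OCc1cn(CCCOc2cc(=O)oc3ccccc23)nn1` gives 5430 nM

In a functional assay on THP-1 cells (Homo sapiens) for cytotoxicity, read by sulforhodamine B assay, with a stated time of 48 h (a higher number here means a weaker inhibitor, a lower number a stronger inhibitor), compound 1 gives 7130 nM and lies within the scatter of both compound 2 and compound 3, so the three values cannot be ranked. Compound 4 `COc1ccc(/C=C/C(=O)/C=C/c2ccc(OCc3cn(CCOc4cc(=O)oc5ccccc45)nn3)c(OC)c2)cc1` has not been measured. Its difference from compound 1 is 4-methoxyphenyl in place of 3-methoxyphenyl on a double-bonded chain carbon bound to a double-bonded chain carbon with 4-methoxyphenyl in place of 3-methoxyphenyl on a double-bonded chain carbon bound to a double-bonded chain carbon. Among the measured compounds shown here, the only measured step at that place is a 1.1-fold higher number from compound 1 to compound 2 (0.04 log units; within the scatter) with furan-2-yl entering, and it stayed within the scatter. No change beyond the scatter is therefore expected in this assay and the expected step is a 1.0-fold lower number from compound 1 to compound 4 (0.01 log units; within the scatter) for this exchange. For compound 4 the estimated value is 7000 nM (expected range 4000 nM to 12000 nM).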

Compound 4, half-maximal inhibitory concentration: 7410 nM
Compound 4: the middle estimate sits 1.1-fold (0.02 log units) below what was measured, within the range that was stated.
By their numbers in this assay, from the lowest: compounds 3, 1, 4 and 2 (each within the scatter of the next).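

In this assay, 4-methoxyphenyl in place of 3-methoxyphenyl on a double-bonded chain carbon bound to a double-bonded chain carbon gives a 1.0-fold higher number from compound 1 to compound 4 (0.02 log units; within the scatter), so this exchange between two methoxyphenyl isomers leaves the number within the scatter. Set against furan-2-yl at the same place, 4-methoxyphenyl gives a 1.1-fold lower number from compound 2 to compound 4 (0.03 log units; within the scatter), so these three groups cannot be told apart in this assay. No available evidence bears on this result. From the compounds shown here alone, whether an amine or a carboxylic acid at this place would move the number beyond the scatter stays open.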